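Benzyl for phenyl on the amine of compound 1

The source may hold more compounds than are shown below. What is called first, only, known or untested is meant among the compounds shown, and "the series" means these compounds.

The series is read in a functional assay on the whole organism (Pleural cavity) with Rattus norvegicus as the target; a higher number here means that more compound is needed for the effect, a lower number that less compound is needed. Compound 1 `OC[C@H]1OC(n2cnc3c(Nc4ccccc4)nccc32)[C@H](O)[C@@H]1O` has so far given only a limit in this assay, > 9 mg/kg. Compound 2 `CN(C)c1nccc2c1ncn2[C@H]1C[C@H](O)[C@@H](CO)O1` likewise returns only a limit in this assay, > 9 mg/kg. Compound 3 `c1ccc(CNc2[nH]ccc3ncnc2-3)cc1`, which carries a benzylamino group on a different core, gives a number in this assay, 9 mg/kg. Two of the three values shown sit at the limit, (the limit of > 9 mg/kg in this assay, at which 2 of the 3 values shown sit), so compound 1 stands where no number has yet been resolved for it.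

Compound 4 `OC[C@H]1OC(n2cnc3c(NCc4ccccc4)nccc32)[C@H](O)[C@@H]1O` keeps the core and the sugar of compound 1 and changes the amine: benzyl in place of phenyl on a nitrogen on an aromatic ring. Cut one bond further out, the change reads anilino to benzylamino. Among the measured compounds shown here, no measured pair in the set differs in just this one place, so the size of the step has no direct precedent here; the nearest point of reference is compound 3, the other benzylamino compound, which gave a number rather than a limit.

A step of a number no higher from compound 1 to compound 4 (the limit leaves the size open) is expected, toward a dose that resolves to a number, but not one beyond the usual scatter. Compound 4 is estimated at 9 mg/kg in this assay, with a range from 4 mg/kg to 20 mg/kg, and a fair chance that only a limit is reported again.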

Compound 4, dose for half-maximal effect: > 9 mg/kg
Compound 4 was reported as a limit; the forecaster's own chance of this, stated with the estimate: 45%; the middle value sits exactly at the limit.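

Compound 1 and compound 4 both stand only as limits in this assay, so no step can be read between them: the limit of > 9 mg/kg in this assay, at which 3 of the 4 values shown sit.

The compounds shown leave open whether benzyl in place of phenyl on a nitrogen on an aromatic ring changes the dose needed at all, and in which direction.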